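Swapping an Ethoxy for a Fluoro on the Pyrimidine

The compounds below may be only part of what the source reports. "The series", "measured", "known", "first", "only" and "open" are said of these compounds alone.

Among the measured compounds shown here, compound 2 `CCOc1cnc(N2CCC([C@H]3C[C@H]3COCc3ccc(S(C)(=O)=O)c(F)c3)CC2)nc1` gives 2.3 nM in a functional assay on isolated protein for agonist activity at Glucose-dependent insulinotropic receptor (Mus musculus), read by cAMP accumulation (a higher number here means that more compound is needed for the effect, a lower number that less compound is needed), the lower of the two numbers measured so far. Compound 1 `CC1(OC(=O)N2CCC([C@H]3C[C@H]3COCc3ccc(-n4cnnn4)cc3F)CC2)CC1` gives 15 nM in this assay, a gap that lies beyond the usual scatter. Compound 3 `CS(=O)(=O)c1ccc(COC[C@@H]2C[C@@H]2C2CCN(c3ncc(F)cn3)CC2)cc1F` is not yet measured and differs from compound 2 in one place: fluoro in place of ethoxy on an aromatic carbon. For the measured compounds named here, no measured pair shows this exact change, so its effect is unknown. Compound 3 is expected to sit slightly higher, near 4 nM, within a range of 1.5 nM to 12 nM. That expected step is a 1.7-fold higher number from compound 2 to compound 3 (0.24 log units; within the scatter), close to the scatter.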

Compound 3, half-maximal effective concentration in the Glucose-dependent insulinotropic receptor assay: 4.5 nM
The estimate for compound 3 lay 1.1-fold (0.05 log units) below the measured number; measured number inside the range.
By their numbers in the Glucose-dependent insulinotropic receptor assay, from the lowest: compounds 2 and 3 (each within the scatter of the next); then compound 1.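

In the Glucose-dependent insulinotropic receptor assay, compound 2 gives 2.3 nM and compound 3 gives 4.5 nM; going from 5-ethoxypyrimidin-2-yl to 5-fluoropyrimidin-2-yl gives a 2.0-fold higher number from compound 2 to compound 3 (0.29 log units; within the scatter), so this position accepts a group of 1 heavy atom as well as one of 3 heavy atoms. In a physicochemical assay for lipophilicity, read by HPLC, at pH 7 (on this read-out higher numbers stand for higher lipophilicity and lower numbers for lower lipophilicity), compound 2 gives 4.2 and compound 3 gives 4.2; the same swap gives no change at the digits printed from compound 2 to compound 3 (within the scatter). No available evidence explains why the two groups read alike. Going by these compounds, what stays open is how an amine or a longer chain such as butoxy would read at this position. Hydrogen in place of the ethoxy would also show whether any group is needed there at all.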